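Aryl Swaps on the Ring Nitrogen: Compound 4 Expected

A few compounds are considered here, and "the series" means these few. Any claim that something is new, unique, unknown or untested is made for them only; others in the source may bear on it.

Measured in a functional assay on SJSA-1 cells (Homo sapiens) for inhibition, read by CCK-8 assay, with a stated time of 72 h, tested at 1 uM; a higher number here means more inhibition at the concentration tested (going by the name of the read-out), a lower number less inhibition:
Compound 1, `Cc1cccc(N2C(=O)CSC2c2cccc(C(=O)NCCCCc3ccccc3)c2)c1`: 84%
Compound 2, `COc1cc(F)ccc1N1C(=O)CSC1c1cccc(C(=O)NCCCCc2ccccc2)c1`: 77%
Compound 3, `O=C(NCCCCc1ccccc1)c1cccc(C2SCC(=O)N2c2ccccc2F)c1`: 80%

Among these three numbers compound 3 stands second highest; its nearest neighbour is compound 2 and its furthest is compound 1, and both of those gaps lie within the scatter. Compound 4, `COc1ccc(N2C(=O)CSC2c2cccc(C(=O)NCCCCc3ccccc3)c2)c(OC)c1`, has not yet been measured in this assay. It differs from compound 3 in one place: 2,4-dimethoxyphenyl in place of 2-fluorophenyl on an amide-type nitrogen in a ring.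

Among the measured compounds shown here, three measured steps bear on this change, since each of them also swaps the aryl group on the ring nitrogen. The step of a number 4 percentage points lower from compound 1 to compound 3 (within the scatter) and the step of a number 3 percentage points higher from compound 2 to compound 3 (within the scatter) both involve the 2-fluorophenyl that leaves, while the step of a number 7 percentage points lower from compound 1 to compound 2 (within the scatter) brings in an aryl group carrying a methoxy, as the entering 2,4-dimethoxyphenyl does. None of these steps exceeds the scatter, so for compound 4 a step of a number 2 percentage points lower from compound 3 to compound 4 (within the scatter) is expected, that is, no change beyond the scatter. Compound 4 is therefore estimated at 78%, within the range 65% to 88%.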

Compound 4, a percentage reported as inhibition, at one concentration (the size of the read-out at that concentration, not a potency): 85%
Estimate against measurement, compound 4: 7 percentage points below; the measured number falls inside the stated range.
By their numbers in this assay, from the lowest: compounds 2, 3, 1 and 4 (each within the scatter of the next).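

In this assay, among the compounds shown here, 2,4-dimethoxyphenyl on the amide-type nitrogen gives a step of a number 5 percentage points higher from compound 3 to compound 4 (within the scatter), and the step of a number 1 percentage points higher from compound 1 to compound 4 (within the scatter) likewise stays within the scatter, so this position accepts a larger aryl group than the earlier compounds showed. Methoxy in place of fluoro on an aromatic carbon, the one-place change a number 8 percentage points higher from compound 2 to compound 4 (within the scatter), also stays within the scatter, so that aromatic carbon takes either group without a change that can be told apart here. No measurement shown explains these numbers.

All four compounds carry a substituted phenyl on that nitrogen, which leaves open how an aryl group bearing an amine or a carboxylic acid, or a cyclohexyl group, would read there. Going by these compounds, with every pair within the scatter at one concentration, any ranking of these aryl groups also stays open.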